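Cytotoxicity of a pyrimidine series: from ethoxy to methoxymethyl

The source may hold more compounds than are shown below. What is called first, only, known or untested is meant among the compounds shown, and "the series" means these compounds.

Three compounds share one core and differ only in the group on an aromatic carbon of the six-membered aromatic ring with two nitrogens. In an ADME assay on MT2 cells (Homo sapiens) for cytotoxicity (a higher number here means that more compound is tolerated, a lower number that less compound is tolerated), compound 1 `CNc1ccnc(Nc2ccc(Cl)c(OCC=C(C)C)c2)n1` gives 690 nM, compound 2 `CSc1ccnc(Nc2ccc(Cl)c(OCC=C(C)C)c2)n1` gives 2800 nM, and compound 3 `CCOc1ccnc(Nc2ccc(Cl)c(OCC=C(C)C)c2)n1` gives 19000 nM. Compound 3 thus stands highest of the three, with a 6.8-fold higher number from compound 2 to compound 3 (0.83 log units; beyond the scatter) and a 28-fold higher number from compound 1 to compound 3 (1.44 log units; beyond the scatter), so it is the best tolerated of the measured set.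

Compound 4 `COCc1ccnc(Nc2ccc(Cl)c(OCC=C(C)C)c2)n1` is the next step: methoxymethyl in place of ethoxy on an aromatic carbon. Within the data shown here, no measured step exchanges these two groups, so the earlier steps bear only indirectly. They show that the group at this carbon moves this assay strongly in every case tried, namely a 4.1-fold higher number from compound 1 to compound 2 (0.61 log units; beyond the scatter), a 28-fold higher number from compound 1 to compound 3 (1.44 log units; beyond the scatter) and a 6.8-fold higher number from compound 2 to compound 3 (0.83 log units; beyond the scatter), and that compound 3 sits alone at the top. Compound 4 is therefore expected to give a lower number than compound 3, a modest step of a 2.4-fold lower number from compound 3 to compound 4 (0.38 log units; beyond the scatter), because compound 3 with 19000 nM has no measured neighbour above it. Compound 4 is estimated at 8000 nM, within a range of 2500 nM to 25000 nM.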

Compound 4, half-maximal cytotoxic concentration: > 25000 nM
Compound 4 was reported as a limit; the forecaster's own chance of this, stated with the estimate: 10%; middle value at least 3.1-fold (0.49 log units) from the limit.
By their numbers in this assay, from the lowest: compound 1; then compound 2; then compound 3. At a limit, above all of these: compound 4.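

In this assay compound 4 is reported only as a limit: the limit of > 25000 nM in this assay, at which 1 of the 4 values shown sits.

Exchanging ethoxy for methoxymethyl, which rearranges the same atoms at this carbon, brings no fall in the number: an at least 1.3-fold higher number from compound 3 to compound 4 (0.11 log units; that floor lies within the scatter). The result therefore shows that a carbon-linked ether group at this position can match the tolerance of the oxygen-linked ethoxy, and both groups stand clear of the two lower members, with an at least 8.9-fold higher number from compound 2 to compound 4 (0.95 log units; beyond the scatter) and an at least 36-fold higher number from compound 1 to compound 4 (1.55 log units; beyond the scatter).

With only a limit for compound 4, the data cannot say whether methoxymethyl and ethoxy truly differ, or by how much. From the compounds shown here alone, whether a longer chain such as methoxyethyl, a primary amine or a carboxylic acid at this carbon would stay at the same high end of the range remains open.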